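Ester to methyl amide on the bromo series: cytotoxicity outlook

A few compounds are considered here, and "the series" means these few. Any claim that something is new, unique, unknown or untested is made for them only; others in the source may bear on it.

Measured so far:
compound 1, `CNC(=O)c1cc(N)c(Nc2ccc(C#N)cc2)cc1Oc1c(OC)cc(CCC#N)cc1OC` — 42600 nM
compound 2, `COC(=O)c1cc(N)c(Nc2ccc(C#N)cc2)cc1Oc1c(Br)cc(CCC#N)cc1OC` — 10100 nM

For the measured compounds named here, the two compounds measured in an ADME assay on TZM cells (Homo sapiens) for cytotoxicity, with a stated time of 1 days (a lower number here means that less compound is tolerated, a higher number that more compound is tolerated), differ in two places, and no single step has been resolved. In this assay compound 2 gives 10100 nM, the lower of the two numbers; compound 1 gives 42600 nM, a higher number that lies beyond the scatter of the method. Compound 3, `CNC(=O)c1cc(N)c(Nc2ccc(C#N)cc2)cc1Oc1c(Br)cc(CCC#N)cc1OC`, differs from compound 2 in one place: methylamino in place of methoxy on a carbonyl carbon. Compound 3 therefore carries the methylcarbamoyl group of compound 1 on the bromo-bearing core of compound 2. Going by the values given here, since no measured pair isolates this change, its effect is not settled; as compound 1 sits higher in this assay, a modest move upward is expected, with the step from compound 2 to compound 3 estimated as a 2.0-fold higher number from compound 2 to compound 3 (0.30 log units; within the scatter), near the edge of the scatter. Compound 3 is accordingly expected to give about 20000 nM in this assay, with a range from 8000 nM to 50000 nM.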

Compound 3, half-maximal cytotoxic concentration in the TZM assay: 52400 nM
Beside the measured number, compound 3's estimate is 2.6-fold (0.42 log units) below it; measured number above the stated range.
By their numbers in the TZM assay, from the lowest: compound 2; then compounds 1 and 3 (each within the scatter of the next).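

In the TZM assay the change of methylamino in place of methoxy on a carbonyl carbon is now a resolved step on the bromo-bearing core: a 5.2-fold higher number from compound 2 to compound 3 (0.72 log units; beyond the scatter) lies beyond the scatter. The other step, bromo in place of methoxy on an aromatic carbon, reads a 1.2-fold higher number from compound 1 to compound 3 (0.09 log units; within the scatter) and shows that with the methylcarbamoyl group in place this exchange gives no resolved difference, so of the two places only the carbonyl carbon has a resolved effect here. In a physicochemical assay for solubility, read by HPLC, in phosphate buffer, with a stated time of 4 h, at pH 7.4, tested at 10 mg/mL (on this read-out higher numbers stand for higher solubility and lower numbers for lower solubility), compound 2 gives 0.2 ug/mL and compound 3 gives 3.38 ug/mL. The methoxycarbonyl to methylcarbamoyl change also goes with a large rise in the physicochemical assay: the measured solubility of compound 2, 0.2 ug/mL, and of compound 3, 3.38 ug/mL, a 17-fold higher number (1.23 log units; beyond the scatter).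

The compounds shown leave open whether the rise in both read-outs is particular to methylamino or would also appear with an ethylamino group or a carboxylic acid on that carbonyl carbon. They also leave open whether the step keeps its size when the aromatic carbon carries methoxy or chloro instead of bromo.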